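Series notes: 1,3-oxazol-2-yl in place of 6-methylpyridin-2-yl

This account rests on a few compounds, and the source may have more. Where it says the series, first, only, none or still open, it means among the compounds named here.

Of the compounds shown here, two on the shared core have been measured in an assay for inhibition of kynurenine 3-monooxygenase (Homo sapiens), read by mass spectrometry, with a stated time of 1 h; a higher number here means a weaker inhibitor, a lower number a stronger inhibitor. Compound 1 `COCCOc1cc2oc(=O)n(CCC(=O)O)c2cc1Cl` gives 31.6 nM. Compound 2 `Cc1cccc([C@@H](C)Oc2cc3oc(=O)n(CCC(=O)O)c3cc2Cl)n1` gives 5.01 nM. Compound 2 therefore holds the lowest of the two numbers, and its nearest neighbour, compound 1, sits higher by a margin beyond the usual scatter.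

Compound 3 `C[C@@H](Oc1cc2oc(=O)n(CCC(=O)O)c2cc1Cl)c1ncco1` is not yet measured in this assay. Its difference from compound 2 is 1,3-oxazol-2-yl in place of 6-methylpyridin-2-yl on a saturated chain carbon bound to an oxygen on an aromatic ring and a saturated chain carbon. Among the measured compounds shown here, no measured pair differs in a single place, so no measured step guides the size of this change; the group that enters is smaller as counted than the one that leaves. The expected step is a 3.0-fold higher number from compound 2 to compound 3 (0.48 log units; beyond the scatter), a moderate move toward a weaker inhibitor, close to the edge of the scatter. The range is kept wide toward higher numbers because compound 1 gives 31.6 nM with a different group in this place. Compound 3 is estimated at 15 nM, expected between 5 nM and 50 nM.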

Compound 3, half-maximal inhibitory concentration in the kynurenine 3-monooxygenase assay: 3.16 nM
The estimate for compound 3 lay 4.7-fold (0.68 log units) above the measured number; measured number outside the range, below it.
By their numbers in the kynurenine 3-monooxygenase assay, from the lowest: compounds 3 and 2 (each within the scatter of the next); then compound 1.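

On this saturated chain carbon, 1,3-oxazol-2-yl serves as well as 6-methylpyridin-2-yl in the kynurenine 3-monooxygenase assay (a 1.6-fold lower number from compound 2 to compound 3 (0.20 log units; within the scatter)), so the smaller five-membered aromatic ring with 2 hetero atoms keeps the number of the six-membered ring, and the group bearing this ring stands clear of the open chain of compound 1 (a 10-fold lower number from compound 1 to compound 3 (1.00 log units; beyond the scatter)). In a physicochemical assay for permeability, using PAMPA (a higher number here means that the compound crosses the layer faster, a lower number that the compound crosses the layer more slowly), compound 2 gives 21 nm/s as a measured number. In the physicochemical assay compound 3 gives < 3 nm/s as a limit of the assay and not a number.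

Open, from the compounds shown here alone, is whether a phenyl ring, or a pyridine ring carrying an amine, on this saturated chain carbon would hold the number of compound 3 in the kynurenine 3-monooxygenase assay as well. Open too, going by these compounds, is what a primary amide in place of the carboxylic acid would give in the physicochemical assay on the core of compound 3.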